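A few compounds are considered here, and "the series" means these few. Any claim that something is new, unique, unknown or untested is made for them only; others in the source may bear on it.

Within the data shown here, in an ADME assay on Huh7.5.1 cells (Homo sapiens) for cytotoxicity, read by ATP content, with a stated time of 48 h (a higher number here means that more compound is tolerated, a lower number that less compound is tolerated), three compounds on a shared core have numbers so far. Compound 1 `CC[C@@H]1C[C@H](CC)CN(CCCNC(=O)C2CCN(Cc3nc(-c4ccccc4C)oc3C)CC2)C1` gives 3470 nM there, compound 2 `Cc1ccccc1-c1nc(CN2CCC(C(=O)NCCCN3CCC(C)CC3)CC2)c(C)o1` gives 12300 nM and compound 3 `Cc1ccccc1-c1nc(CN2CCC(C(=O)NCCN3C[C@H](C)C[C@H](C)C3)CC2)c(C)o1` gives 24400 nM at the tolerated end of the set, alongside compound 2. Among the measured compounds shown here, only one neighbour is clearly separated from it: the data show a 7.0-fold higher number from compound 1 to compound 3 (0.85 log units; beyond the scatter) against a 2.0-fold higher number from compound 2 to compound 3 (0.30 log units; within the scatter) as the other gap.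

Compound 4 `CCCN(CCC)CCNC(=O)C1CCN(Cc2nc(-c3ccccc3C)oc2C)CC1` differs from compound 3 by dipropylamino in place of 3,5-dimethylpiperidin-1-yl on a saturated chain carbon, two bonds along the chain from an amide-type nitrogen and so has no ring in the entering group. For the measured compounds named here, no measured compound lacks a ring at this place, so the measured steps bear on the change only indirectly. Besides the two gaps above, the one remaining step is a 3.5-fold higher number from compound 1 to compound 2 (0.55 log units; beyond the scatter) and, like the step to compound 3, it starts from compound 1. No step beyond the scatter is therefore expected here, and the expected change is a 1.4-fold lower number from compound 3 to compound 4 (0.13 log units; within the scatter) in this assay with no firm direction. The estimate for compound 4 is 18000 nM with an expected range from 8000 nM to 36000 nM in all.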

Compound 4, half-maximal cytotoxic concentration: 30500 nM
The estimate for compound 4 lay 1.7-fold (0.23 log units) below the measured number, and the stated range covers the measured number.
By their numbers in this assay, from the lowest: compound 1; then compounds 2, 3 and 4 (each within the scatter of the next, the first and the last beyond it).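

Among these compounds, compound 4 is the first here with no ring in the entering group, and dipropylamino is tolerated on a par with 3,5-dimethylpiperidin-1-yl, with a 1.3-fold higher number from compound 3 to compound 4 (0.10 log units; within the scatter) in this assay. Compound 4 also stands clear of compound 2, at a 2.5-fold higher number from compound 2 to compound 4 (0.39 log units; beyond the scatter), a separation that compound 3 did not reach, and it sits furthest from compound 1, at an 8.8-fold higher number from compound 1 to compound 4 (0.94 log units; beyond the scatter). Nothing available explains these numbers.

The steps from compound 1 and compound 2 change the amine and the length of the chain together, so dipropylamino on the longer chain would be needed to separate the two. Going by these compounds, whether the same tolerance extends to a smaller open amine such as dimethylamino, or to a ring with a second hetero atom such as morpholin-4-yl, also remains open.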